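Removing the Cyclopropyl Ring While Keeping the Methoxy

A few compounds are considered here, and "the series" means these few. Any claim that something is new, unique, unknown or untested is made for them only; others in the source may bear on it.

In an ADME assay on microsomes from liver (Homo sapiens) for metabolic stability, read by HPLC, with a stated time of 10 min, tested at 3 uM (a higher number here means that more of the compound is left, a lower number that less of the compound is left), compound 1 `COC[C@H](C1CC1)n1cc(Cl)nc(Nc2cc(C)c(OC)nc2C)c1=O` gives 48%. Compound 2 `COC[C@@H](C1CC1)n1cc(Cl)nc(Nc2cc(C)c(OC)nc2C)c1=O`, which differs only in configuration as drawn, gives 40%, so the pair shows a number 8 percentage points lower from compound 1 to compound 2 (within the scatter). Compound 3 `COc1nc(C)c(Nc2nc(Cl)cn([C@H](C)C3CC3)c2=O)cc1C` gives 77%, the highest of the three, which leaves compound 1 well under it.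

Compound 4 `COC[C@@H](C)n1cc(Cl)nc(Nc2cc(C)c(OC)nc2C)c1=O` alters compound 1 at one place: 1-(methoxymethyl)ethyl in place of 1-cyclopropyl-2-methoxyethyl on an aromatic nitrogen. The cyclopropyl ring goes and the methoxy stays. Among the compounds with values here, no measured step removes that ring alone. The nearest steps remove the methoxy and keep the ring: a number 29 percentage points higher from compound 1 to compound 3 (beyond the scatter) and a number 37 percentage points higher from compound 2 to compound 3 (beyond the scatter). Compound 4 does not make that change, so neither rise is expected to carry over. The drawn configuration of compound 4 should matter little, given a number 8 percentage points lower from compound 1 to compound 2 (within the scatter). Only a small change, within the scatter, is therefore expected, and the direction is uncertain. The expected step is a number 4 percentage points higher from compound 1 to compound 4 (within the scatter). For compound 4 the estimated value is 52%, with an expected range of 35% to 70%.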

Compound 4, percent of the compound remaining: 39%
Beside the measured number, compound 4's estimate is 13 percentage points above it; measured number inside the range.
By their numbers in this assay, from the lowest: compounds 4, 2 and 1 (each within the scatter of the next); then compound 3.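

In this assay, the cyclopropyl ring can go while the methoxy stays with no change beyond the scatter (a number 9 percentage points lower from compound 1 to compound 4 (within the scatter)), and the picture is the same against the other drawn configuration (a number 1 percentage points lower from compound 2 to compound 4 (within the scatter)). Within the data shown here, the three methoxy-bearing compounds therefore sit together, while the one compound without a methoxy keeps the ring and stands clear of them (a number 38 percentage points lower from compound 3 to compound 4 (beyond the scatter)). Nothing at hand explains this result.

The compounds shown leave open how an isopropyl group, with neither the ring nor the methoxy, would behave on this aromatic nitrogen, and whether a hydroxyl or an ethoxy in place of the methoxy would give a number closer to the methoxy compounds or to the one without it. As far as these compounds go, the opposite configuration of the new side chain also remains open.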